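The source may report more compounds than this note shows. Statements on the series, on what has been measured and on what is new or still open speak of the compounds shown alone.

Measured so far in a functional assay on HepG2 cells (Homo sapiens) for cytotoxicity, read by MTT assay, with a stated time of 72 h; on this read-out higher numbers stand for weaker inhibition and lower numbers for stronger inhibition:
compound 1, `COc1ccc(C(=O)NC[C@H]2c3[nH]c4ccccc4c3C[C@H]3[C@H]4c5[nH]c6ccccc6c5C[C@@H]([C@H](C#N)N23)N4C)cc1`, gives 310 nM
compound 2, `CCc1ccc(C(=O)NC[C@H]2c3[nH]c4ccccc4c3C[C@H]3[C@H]4c5[nH]c6ccccc6c5C[C@@H]([C@H](C#N)N23)N4C)cc1`, gives 570 nM

Compound 2 stands at the higher of the two numbers in this assay; its nearest neighbour is compound 1, and the step of a 1.8-fold higher number from compound 1 to compound 2 (0.26 log units; within the scatter) lies within the scatter, so the two compounds cannot be ordered.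

Compound 3, `CN1[C@@H]2c3[nH]c4ccccc4c3C[C@H]1[C@H](C#N)N1[C@@H](CNC(=O)c3cc4ccccc4[nH]3)c3[nH]c4ccccc4c3C[C@@H]21`, is not yet measured. It differs from compound 2 by 1H-indol-2-yl in place of 4-ethylphenyl on a carbonyl carbon; the change therefore replaces the whole aromatic ring bearing the ethyl group with a fused bicyclic group carrying an amide-type ring hydrogen, while the amide and the shared core are kept.

Going by the values given here, the only measured step, a 1.8-fold higher number from compound 1 to compound 2 (0.26 log units; within the scatter), exchanges one small substituent on the retained aromatic ring and stays within the scatter. Among the compounds with values here, no measured step exchanges the aromatic ring itself, so the data give no direction for the present change. The expectation for compound 3 is therefore a step of a 1.1-fold lower number from compound 2 to compound 3 (0.06 log units; within the scatter) not beyond the scatter, with a wide range to allow for the untested ring exchange. Compound 3 is estimated at 500 nM, between 150 nM and 1700 nM, in this assay.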

Compound 3, half-maximal inhibitory concentration: 440 nM
Beside the measured number, compound 3's estimate is 1.1-fold (0.06 log units) above it, and the stated range covers the measured number.
By their numbers in this assay, from the lowest: compounds 1, 3 and 2 (each within the scatter of the next).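

Exchanging the whole aromatic ring on the carbonyl carbon, and not just a small substituent on it, is now covered in this assay: 1H-indol-2-yl in place of 4-ethylphenyl gives a 1.3-fold lower number from compound 2 to compound 3 (0.11 log units; within the scatter), and in place of 4-methoxyphenyl gives a 1.4-fold higher number from compound 1 to compound 3 (0.15 log units; within the scatter). Compounds 1, 2 and 3 therefore cannot be ordered, and within these three compounds neither the fused bicyclic group nor its ring nitrogen separates compound 3 from the two phenyl amides. No available evidence accounts for this result.

The compounds shown all keep an aromatic group on the carbonyl carbon, so it remains open whether a saturated cyclohexyl group or a simple methyl there would stay in the same range. Also open, going by these compounds, is how a phenyl ring carrying a carboxylic acid or an amine would read out.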